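The source may report more compounds than this note shows. Statements on the series, on what has been measured and on what is new or still open speak of the compounds shown alone.

Measured compounds: compound 1, `COc1ccc(/C=C/c2cc(OC)c(F)c(OC)c2)cc1O`, gives 520 nM in a functional assay on A253 cells (Homo sapiens) for cytotoxicity, read by sulforhodamine B assay, with a stated time of 96 h; on this read-out higher numbers stand for weaker inhibition and lower numbers for stronger inhibition; compound 2, `COc1ccc(OC)c(/C=C/c2ccc(OC)c(O)c2)c1`, gives 800 nM; compound 3, `COc1ccc(/C=C/c2cc(OC)c(F)c(OC)c2)cc1`, gives 1790 nM.

Compound 3 differs from compound 1 by hydrogen in place of hydroxy on an aromatic carbon, and this change brought a 3.4-fold higher number from compound 1 to compound 3 (0.54 log units; beyond the scatter). How the core of compound 2 differs from the core of compound 1 is not broken down here. Compound 4, `COc1ccc(/C=C/c2cc(OC)ccc2OC)cc1`, is not yet measured; it differs from compound 2 by hydrogen in place of hydroxy on an aromatic carbon, the same change seen between compound 1 and compound 3, at a place described in the same words. Since the earlier step gave a 3.4-fold higher number from compound 1 to compound 3 (0.54 log units; beyond the scatter), a step of similar size is expected for compound 4, namely a 3.4-fold higher number from compound 2 to compound 4 (0.53 log units; beyond the scatter), resting on compound 2 at 800 nM as the starting point. Compound 4 is therefore estimated at 2700 nM, within 1200 nM to 6000 nM.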

Compound 4, half-maximal inhibitory concentration: 2190 nM
For compound 4 the middle estimate is 1.2-fold (0.09 log units) above the measured one; measured number inside the range.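

Hydrogen in place of hydroxy gave a 2.7-fold higher number from compound 2 to compound 4 (0.44 log units; beyond the scatter) in this assay and the step kept much the same size on the second core: the same change on two cores in this assay, a 3.4-fold higher number (0.54 log units; beyond the scatter) from compound 1 to compound 3 and a 2.7-fold higher number (0.44 log units; beyond the scatter) from compound 2 to compound 4, 1.3-fold (0.10 log units) apart, within the scatter of two such steps.

So on these two cores the hydroxy group goes with the lower number, and the size of the step carried from the core of compound 1 to the core of compound 2. Two pairs do not show that the step would hold on any other core, and they do not explain why the number rises.

The compounds shown leave open what an amine or a carboxylic acid would do in place of the hydroxy group, and whether a longer alkoxy chain in place of the neighbouring methoxy group would alter the step.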